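A few compounds are considered here, and "the series" means these few. Any claim that something is new, unique, unknown or untested is made for them only; others in the source may bear on it.

Compound 1 `CC(C)(C)c1[nH]cnc1/C=c1\[nH]c(=O)/c(=C/c2ccccc2)nc1OCOC(=O)CCCc1cn(C[C@H](O)CC(=O)O)nn1`: 850 ug/mL
Compound 2 `CC(C)(C)c1[nH]cnc1/C=c1\[nH]c(=O)/c(=C/c2ccccc2)nc1OCOC(=O)CCCc1cn([C@@H](CCC(=O)O)C(=O)O)nn1`: > 100000 ug/mL

Of the compounds shown here, two have been measured so far. In a physicochemical assay for solubility, read by HPLC, with a stated time of 15 min (on this read-out lower numbers stand for lower solubility and higher numbers for higher solubility), compound 1 gives 850 ug/mL. In this assay compound 2 gives > 100000 ug/mL. The reading for compound 2 is a limit of the assay and not a number: compound 2 sits at the limit of > 100000 ug/mL in this assay, at which 1 of the 2 values shown sits, so only a lower bound of its solubility is known, not where it truly lies.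

Within the data shown here, the one measured step, an at least 110-fold higher number from compound 1 to compound 2 (2.07 log units; beyond the scatter), came from exchanging one substituent for another on an aromatic nitrogen, and it reached the limit.

Compound 3 `CC(C)(C)c1[nH]cnc1/C=c1\[nH]c(=O)/c(=C/c2ccccc2)nc1OCOC(=O)CCCc1cn([C@H](CCC(=O)O)C(=O)O)nn1` has not been measured. It differs from compound 2 only in configuration: the two compounds have the same atoms and bonds and differ only in configuration as drawn: 1 of 3 stereo elements differ; a stereocentre at a saturated chain carbon is drawn S in compound 2 and R in compound 3. Among the measured compounds shown here, no measured step covers a change of configuration alone, so the step from compound 1 to compound 2 offers no direct guide; the two compounds share every atom and bond.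

For compound 3 the expected step in this assay is a number no higher from compound 2 to compound 3 (the limit leaves the size open), none beyond the scatter. The estimate for compound 3 is 100000 ug/mL, between 30000 ug/mL and 300000 ug/mL, most probably again reported only as a limit.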

Compound 3, solubility: > 100000 ug/mL
Compound 3: only a limit was reported; the forecaster's own chance of this, stated with the estimate: 80%; the middle value sits exactly at the limit.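

In this assay compound 3 gives > 100000 ug/mL as its reading, which is a limit of the assay and not a number. Drawn with the R configuration, the 1,3-dicarboxypropyl group in place of 3-carboxy-2-hydroxypropyl on the aromatic nitrogen gives an at least 110-fold higher number from compound 1 to compound 3 (2.07 log units; beyond the scatter) and so the large rise seen earlier with the S configuration is not confined to that one drawing of the stereocentre. The step between compound 2 and compound 3 cannot be read, and any difference that the configuration makes stays hidden at this ceiling: the limit of > 100000 ug/mL in this assay, at which 2 of the 3 values shown sit.

From the compounds shown here alone, how far past the limit compound 2 and compound 3 truly lie remains open, and so does whether their configuration matters at all for this read-out at lower, readable values. Also open, going by these compounds, is whether another group on the same aromatic nitrogen, such as an amine or a sulfonic acid, would reach the same limit or stop short of it.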